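The compounds below may be only part of what the source reports. "The series", "measured", "known", "first", "only" and "open" are said of these compounds alone.

In an assay on HEK293 cells for inhibition of sodium-dependent dopamine transporter (Homo sapiens), read by scintillation counting, with a stated time of 5 min (on this read-out lower numbers stand for stronger inhibition and higher numbers for weaker inhibition), the three measured compounds give little to build on. Compound 1 `Cc1c(CN([C@@H]2CCNC2)S(C)(=O)=O)ccc2cc(F)ccc12` reaches only a limit of the assay, at > 28000 nM. Compound 3 `CS(=O)(=O)N(Cc1ccc2ccccc2c1)[C@@H]1CCNC1` likewise reaches only a limit, at > 68000 nM. Both of these are amide-type sulfonyl compounds, and neither gives a number; the two limits stand as the limit of > 28000 nM in this assay, at which 1 of the 3 values shown sits, and (the limit of > 68000 nM in this assay, at which 1 of the 3 values shown sits). Compound 2 `O=C(NC1CCNCC1)c1ccc2ccccc2c1`, the amide that matters for the step in hand, stands apart: in this assay compound 2 is recorded as "not determined" (no result reported), so no number is known for it. The two further values that surround it, those of compound 1 and compound 3, are not numbers either.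

Compound 4 `O=C(c1ccc2ccccc2c1)N(C1CCC1)C1CCNCC1` differs from compound 2 by a single change: cyclobutyl in place of hydrogen on an amide-type nitrogen. With no measured step between compound 2 and compound 4 and no number for compound 2, the size and direction of the change cannot be read from any pair shown, and the expectation is worded only from the weak showing of the two measured neighbours. On that footing compound 4 is expected to sit near 30000 nM in this assay, with a range from 5000 nM to 100000 nM, and it is as likely as not that only a limit would be reported for it.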

Compound 4, half-maximal inhibitory concentration: > 40000 nM
Compound 4: only a limit was reported (the forecaster's own chance of this, stated with the estimate: 55%); at least 1.3-fold (0.12 log units) between middle value and limit.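

Compound 4 gives only a limit, > 40000 nM. With no number for compound 2 either, no step can be read between compound 2 and compound 4. The compounds shown leave open whether cyclobutyl in place of hydrogen on the amide-type nitrogen changes the read-out at all, and what number any of these compounds would give in this assay.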